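The source may report more compounds than this note shows. Statements on the series, on what has been measured and on what is new or still open speak of the compounds shown alone.

In a functional assay on DU-145 cells (Homo sapiens) for inhibition, read by MTT assay, with a stated time of 2 days (on this read-out lower numbers stand for stronger inhibition of growth and higher numbers for weaker inhibition of growth), compound 1, with structure `O=C(Nn1c(-c2ccccc2)nc2c(-c3ccc(Cl)cc3)n[nH]c2c1=O)c1ccccc1`, gives 20100 nM. Compound 2, `CCCCCc1nc2c(-c3ccc(Cl)cc3)n[nH]c2c(=O)n1NC(=O)c1ccccc1`, gives 22100 nM in this assay, a change of a 1.1-fold higher number from compound 1 to compound 2 (0.04 log units; within the scatter). Compound 3, `CCCCCc1nc2c(-c3ccc(Cl)cc3)n[nH]c2c(=O)n1NC(=O)c1cccc(C)c1`, gives 12900 nM in this assay, a change of a 1.7-fold lower number from compound 2 to compound 3 (0.23 log units; within the scatter). Compound 3 thus carries the lowest of the three numbers, yet its gaps to compound 1 and compound 2 both lie within the scatter, so the three compounds stand as one group.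

Compound 4, `Cc1cccc(C(=O)Nn2c(CC3CCCCC3)nc3c(-c4ccc(Cl)cc4)n[nH]c3c2=O)c1`, differs from compound 3 by cyclohexyl in place of butyl on a saturated chain carbon bound to an aromatic carbon. Within the data shown here, the only measured step touching that position is the one from compound 1 to compound 2, which was small, so no shift beyond the scatter is expected in this assay for compound 4, an expected step of a 1.1-fold lower number from compound 3 to compound 4 (0.03 log units; within the scatter). Compound 4 is therefore estimated at 12000 nM, with a range from 5000 nM to 30000 nM.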

Compound 4, concentration for 50% growth inhibition: 1070 nM
Compound 4: the middle estimate sits 11-fold (1.05 log units) above what was measured, outside the stated range (below it).
By their numbers in this assay, from the lowest: compound 4; then compounds 3, 1 and 2 (each within the scatter of the next).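

Moving from an open chain to a ring at this position on the saturated chain matters in this assay: cyclohexyl in place of butyl gives a 12-fold lower number from compound 3 to compound 4 (1.08 log units; beyond the scatter). The earlier change near this site, a 1.1-fold higher number from compound 1 to compound 2 (0.04 log units; within the scatter), lay within the scatter, so those compounds gave no sign that this position could respond so strongly.

As far as these compounds go, whether cyclopentyl, phenyl or a ring carrying an amine would do the same at this position remains open. Nothing available here explains why the cyclohexyl change has so large an effect.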